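The source may report more compounds than this note shows. Statements on the series, on what has been measured and on what is new or still open speak of the compounds shown alone.

Compound 1 (`COc1ccc(-c2ccc3c(c2)oc(=O)n3C(=O)NCCCCc2ccccc2)cc1`): 2.2 h
Compound 2 (`COc1ccc(-c2ccc3oc(=O)n(C(=O)NCCCCc4ccccc4)c3c2)cc1`): 2.93 h

Among the measured compounds shown here, in a physicochemical assay for metabolic stability, read by HPLC, in phosphate buffer, at pH 7.4, tested at 10 uM (on this read-out higher numbers stand for a longer-lived compound and lower numbers for a shorter-lived compound), compound 1 stands at 2.2 h and lies within the scatter of compound 2 at 2.93 h on the only two numbers so far. Compound 3 (`O=C(NCCCCc1ccccc1)n1c(=O)oc2cc(-c3ccccc3)ccc21`) departs from compound 1 by one change, (hydrogen in place of methoxy on an aromatic carbon), which is hydrogen in place of methoxy on an aromatic carbon. For the measured compounds named here, no measured pair shows this change, and no step beyond the scatter is expected in this assay for it. The expected move is a 1.1-fold higher number from compound 1 to compound 3 (0.04 log units; within the scatter) and it stays inside the scatter. Compound 3 is expected at 2.4 h within an estimated range from 1.3 h to 4.4 h.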

Compound 3, half-life: > 5 h
Compound 3 gave a limit, no number; the forecaster's own chance of this, stated with the estimate: 2%; middle value at least 2.0-fold (0.31 log units) from the limit.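

In this assay, the change from 4-methoxyphenyl to phenyl gives an at least 2.2-fold higher number from compound 1 to compound 3 (0.35 log units; beyond the scatter), the first step beyond the scatter among these compounds, and it shows that the group on this aromatic carbon, para to a large group, can shift the half-life. Compound 3 reads > 5 h, which is a limit of the assay and not a number. The true size of the step therefore stays unknown, and it rests on a limit: the limit of > 5 h in this assay, at which 1 of the 3 values shown sits.

On these data alone, this is a single pair, so it remains open whether the same change would give a similar step on the core of compound 2. As far as these compounds go, how fluorine or an amine at this place would read also remains open.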